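The source may report more compounds than this note shows. Statements on the series, on what has been measured and on what is new or still open speak of the compounds shown alone.

Within the data shown here, the two compounds measured so far share one core. Compound 1 `Cc1c(F)c(Oc2cccc(CC(N)=O)c2)nc(Oc2cccc(C(=N)N)c2)c1F` carries a carbamoylmethyl group, and in an assay on isolated protein for inhibition of serine protease 1 (Bos taurus) (on this read-out higher numbers stand for weaker inhibition and lower numbers for stronger inhibition), compound 1 gives only a limit, > 5000 nM. Compound 2 `Cc1c(F)c(Oc2cccc(C(=N)N)c2)nc(Oc2cccc(C(=O)C(C)C)c2)c1F` carries an isopropylcarbonyl group in its place, and in this assay compound 2 gives 3800 nM. The step of an at least 1.3-fold lower number from compound 1 to compound 2 (0.11 log units; that floor lies within the scatter) rests on the limit of > 5000 nM in this assay, at which 1 of the 2 values shown sits, and therefore tells little about size or direction. Compound 2 thus holds the only number shown in this assay; the other value is a limit.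

Compound 3 `Cc1c(F)c(Oc2cccc(C(=N)N)c2)nc(Oc2cccc([S+]([O-])N(C)C)c2)c1F` differs from compound 2 in one place: a group of 5 heavy atoms (2 carbon, 1 nitrogen, 1 oxygen, 1 sulfur; no ring) in place of a group of 5 heavy atoms (4 carbon, 1 oxygen; no ring), on an aromatic carbon. No measured step involves this new group, and the single step shown, from compound 1 to compound 2, lies within the scatter, so the step of a 1.2-fold higher number from compound 2 to compound 3 (0.07 log units; within the scatter) is expected to stay within the scatter as well. Compound 3 is therefore expected to give 4500 nM in this assay, with a range from 1500 nM to 15000 nM.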

Compound 3, inhibition constant: 2400 nM
Beside the measured number, compound 3's estimate is 1.9-fold (0.27 log units) above it; the measured number falls inside the stated range.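

On this aromatic carbon, replacing isopropylcarbonyl with the group holding sulfur and nitrogen gives a 1.6-fold lower number from compound 2 to compound 3 (0.20 log units; within the scatter) in this assay, so these two groups cannot be told apart in this assay. Measured against carbamoylmethyl, the same group gives the only step shown that lies beyond the scatter, an at least 2.0-fold lower number from compound 1 to compound 3 (0.31 log units; beyond the scatter). That step gives only a floor for the size of the change, and it rests on a limit: the limit of > 5000 nM in this assay, at which 1 of the 3 values shown sits.

The compounds shown leave open how large the step from carbamoylmethyl really is, and whether any group on this carbon can move the number beyond the scatter relative to compound 2 and compound 3. An amine, a carboxylic acid or a longer carbon chain in this place would bear on that question.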